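Swapping a Bromo Group for a Fluorophenylamino Group

The compounds below may be only part of what the source reports. "The series", "measured", "known", "first", "only" and "open" are said of these compounds alone.

Two amides built on the same core have been tested. Compound 1, `C=CCOc1ccc(C(=O)Nc2cccc(C)n2)cc1`, carries a methyl group on its pyridine-like ring and an allyloxy group on the benzene ring; in an in vitro assay on HEK-tsA201 cells for antagonist activity at Neuronal acetylcholine receptor; alpha3/beta4 (Homo sapiens), read by fluorescence and calcium flux (a lower number here means a stronger inhibitor, a higher number a weaker inhibitor), compound 1 gives 31700 nM. Compound 2, `CCCOc1ccc(C(=O)Nc2cccc(Br)n2)cc1`, carries a propoxy group instead and a bromo group in place of the methyl. In this assay compound 2 gives only a limit, > 100000 nM, which is an edge of the assay rather than a number. For compound 2 the measurement stopped at the limit of > 100000 nM in this assay, at which 1 of the 2 values shown sits, so compound 2 is at best a weak inhibitor and could be far weaker.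

The next compound, compound 3, `CCCOc1ccc(C(=O)Nc2cccc(Nc3ccc(F)cc3)n2)cc1`, differs from compound 2 in one place: (4-fluorophenyl)amino in place of bromo on an aromatic carbon. Within the data shown here, since no step between measured compounds is known, the size of this change in this assay can only be guessed. Compound 3 is expected to show a modest gain, an at least 2.5-fold lower number from compound 2 to compound 3 (0.39 log units; beyond the scatter), though the limit on compound 2 makes the true step uncertain. Compound 3 is estimated at 40000 nM, likely between 8000 nM and 100000 nM.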

Compound 3, half-maximal inhibitory concentration: > 100000 nM
Compound 3: only a limit was reported; the forecaster's own chance of this, stated with the estimate: 40%; middle value at least 2.5-fold (0.39 log units) away from the limit.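

In this assay compound 3 gives only a limit, > 100000 nM. No step can be read from compound 2 to compound 3, because both stop at the same edge of the assay: the limit of > 100000 nM in this assay, at which 2 of the 3 values shown sit.

The compounds shown leave open whether (4-fluorophenyl)amino in place of bromo changes inhibition at all, and how far either compound lies past that edge.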